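Amino in Place of Chloro on the Shared Core

The source may hold more compounds than are shown below. What is called first, only, known or untested is meant among the compounds shown, and "the series" means these compounds.

Two compounds have been measured in a functional assay on U-251 cells (Homo sapiens) for antiproliferative activity, read by sulforhodamine B assay, with a stated time of 48 h; on this read-out lower numbers stand for stronger inhibition of growth and higher numbers for weaker inhibition of growth:
Compound 1 `Nc1nn(C(=O)Nc2ccc(Cc3ccccc3)cc2)c2ccccc12` gives 30200 nM.
Compound 2 `Nc1nn(C(=O)Nc2ccc(Cc3ccccc3)cc2)c2ccc(Cl)cc12` gives 27000 nM.

Compound 2 stands at the lower end of these two numbers, yet the step of a 1.1-fold lower number from compound 1 to compound 2 (0.05 log units; within the scatter) lies within the scatter, so the two compounds are not distinguished. Compound 3 `Nc1ccc2c(c1)c(N)nn2C(=O)Nc1ccc(Cc2ccccc2)cc1` differs from compound 2 by amino in place of chloro on an aromatic carbon. Going by the values given here, the only measured step, a 1.1-fold lower number from compound 1 to compound 2 (0.05 log units; within the scatter), concerned the same position and stayed within the scatter; no step involving amino has been measured. A change no larger than the scatter is therefore expected in this assay. Compound 3 is estimated at 28000 nM, with a range from 12000 nM to 65000 nM. This means an expected 1.0-fold higher number from compound 2 to compound 3 (0.02 log units; within the scatter).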

Compound 3, concentration for total growth inhibition: 20900 nM
For compound 3 the middle estimate is 1.3-fold (0.13 log units) above the measured one, within the range that was stated.
By their numbers in this assay, from the lowest: compounds 3, 2 and 1 (each within the scatter of the next).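

At this position on the shared core, amino can now be set beside both chloro and hydrogen, and in this assay the steps are a 1.3-fold lower number from compound 2 to compound 3 (0.11 log units; within the scatter) and a 1.4-fold lower number from compound 1 to compound 3 (0.16 log units; within the scatter). Amino, with its hydrogen-bond donor, is thus not distinguished here from either chloro or hydrogen. No evidence is available to explain this result. The compounds shown leave open whether a carboxylic acid, a methoxy group or a longer chain at this position would give a step beyond the scatter.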